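Swapping chloro for fluoro on a macrocyclic sulfonamide

A few compounds are considered here, and "the series" means these few. Any claim that something is new, unique, unknown or untested is made for them only; others in the source may bear on it.

Compound 1 `COc1ccc2c(OCC[C@@H]3NC(=O)N(C)CCCC/C=C\[C@@H]4C[C@@]4(C(=O)NS(=O)(=O)C4(C)CC4)NC3=O)cc(-c3nc(C(C)C)cs3)nc2c1F`: 57100 nM
Compound 2 `COc1ccc2c(OCC[C@@H]3NC(=O)N(C)CCCC/C=C\[C@@H]4C[C@@]4(C(=O)NS(=O)(=O)C4CC4)NC3=O)cc(-c3nc(C(C)C)cs3)nc2c1Cl`: 40400 nM
Compound 3 `COc1ccc2c(OCC[C@@H]3NC(=O)N(C)CCCC/C=C\[C@@H]4C[C@@]4(C(=O)NS(=O)(=O)N4CCOCC4)NC3=O)cc(-c3nc(C(C)C)cs3)nc2c1Cl`: 26400 nM

These three compounds were tested in an ADME assay on cells (Homo sapiens) for activation; a higher number here means that more compound is tolerated, a lower number that less compound is tolerated. Compound 2 sits between compound 1 and compound 3, and both gaps are within the scatter, so the three numbers cannot be told apart. Compound 4 `COc1ccc2c(OCC[C@@H]3NC(=O)N(C)CCCC/C=C\[C@@H]4C[C@@]4(C(=O)NS(=O)(=O)C4CC4)NC3=O)cc(-c3nc(C(C)C)cs3)nc2c1F` is compound 2 with one change: fluoro in place of chloro on an aromatic carbon. Within the data shown here, no measured step tests exactly this change. Among the measured compounds shown here, the only measured step, a 1.5-fold lower number from compound 2 to compound 3 (0.18 log units; within the scatter), concerns a different part of the molecule and was within the scatter. Compound 1 carries the fluoro but also differs elsewhere, so its value only hints that the fluoro compounds are not less tolerated. Compound 4 is therefore expected to show a 1.2-fold higher number from compound 2 to compound 4 (0.07 log units; within the scatter), a step not beyond the scatter, with an estimate of 47000 nM in this assay, within 24000 nM to 90000 nM.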

Compound 4, half-maximal cytotoxic concentration: > 75000 nM
Compound 4 gave a limit, no number; the forecaster's own chance of this, stated with the estimate: 5%; middle value at least 1.5-fold (0.20 log units) from the limit.
By their numbers in this assay, from the lowest: compounds 3, 2 and 1 (each within the scatter of the next, the first and the last beyond it). At a limit, above all of these: compound 4.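

Compound 4 gives a limit, not a number: > 75000 nM. At the aromatic carbon ortho to a methoxy group, fluoro in place of chloro gives an at least 1.8-fold higher number from compound 2 to compound 4 (0.26 log units; that floor lies within the scatter), while hydrogen in place of methyl on a saturated ring carbon gives an at least 1.3-fold higher number from compound 1 to compound 4 (0.11 log units; that floor lies within the scatter). Among these compounds, the earlier compounds held no pair for the chloro and fluoro swap at this position, and because each step here is only a floor, its true size stays unknown.

From the compounds shown here alone, how a nitrile or an amine on this aromatic carbon would read remains open. So does the reading of morpholin-4-yl on the sulfonyl sulfur alongside fluoro.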